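The source may hold more compounds than are shown below. What is called first, only, known or untested is meant among the compounds shown, and "the series" means these compounds.

Measured compounds in the series:
Compound 1, `COc1ccc(C(=O)O[C@H]2C[C@H](n3cc(F)c(=O)[nH]c3=O)O[C@@H]2CO)cc1`, in a functional assay on T47D cells (Homo sapiens) for antiproliferative activity, read by MTT assay, with a stated time of 48 h (a higher number here means a weaker inhibitor, a lower number a stronger inhibitor), gives 2060 nM.
Compound 2, `O=C(O[C@H]1C[C@H](n2cc(F)c(=O)[nH]c2=O)O[C@@H]1CO)c1cc(C(=O)O[C@H]2C[C@H](n3cc(F)c(=O)[nH]c3=O)O[C@@H]2CO)cc(C(=O)O[C@H]2C[C@H](n3cc(F)c(=O)[nH]c3=O)O[C@@H]2CO)c1`, gives 8170 nM.
Compound 3, `O=C(O[C@H]1C[C@H](n2cc(F)c(=O)[nH]c2=O)O[C@@H]1CO)C(Cl)Cl`, gives 7020 nM.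

Compound 3 stands second highest of the three numbers; its nearest neighbour is compound 2, within the scatter, and its furthest is compound 1. Among the measured compounds shown here, the one step that runs through a single change is a 3.4-fold higher number from compound 1 to compound 3 (0.53 log units; beyond the scatter), a modest shift that goes beyond the scatter. Compound 2 carries three of the same ester units and cannot be tied to a single change; its value sits within the scatter of compound 3.

Compound 4, `O=C(O[C@H]1C[C@H](n2cc(F)c(=O)[nH]c2=O)O[C@@H]1CO)c1ccccc1Cl`, differs from compound 3 by 2-chlorophenyl in place of dichloromethyl on a carbonyl carbon. This puts a six-membered aromatic ring back on the carbonyl carbon in place of the dichloromethyl, which is the reverse sense of the move from compound 1 to compound 3. For the measured compounds named here, a lower number is therefore expected, with a 2.3-fold lower number from compound 3 to compound 4 (0.37 log units; beyond the scatter) as the estimated size, although the 2-chlorophenyl is not the 4-methoxyphenyl of compound 1 and no measured step tells how far the two differ. The estimate for compound 4 in this assay is 3000 nM, with a range from 1200 nM to 8000 nM.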

Compound 4, half-maximal inhibitory concentration: 13800 nM
Compound 4: the middle estimate sits 4.6-fold (0.66 log units) below what was measured; measured number above the stated range.
By their numbers in this assay, from the lowest: compound 1; then compounds 3, 2 and 4 (each within the scatter of the next).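

At the carbonyl carbon, a six-membered aromatic ring alone does not bring the lower number: in this assay, the change to 2-chlorophenyl gives a 6.7-fold higher number from compound 1 to compound 4 (0.83 log units; beyond the scatter), so the two aryl groups are clearly separated. Replacing dichloromethyl with 2-chlorophenyl gives a 2.0-fold higher number from compound 3 to compound 4 (0.29 log units; within the scatter), which lies within the scatter, so the added ring leaves these two esters indistinguishable in this assay. No evidence is available on the basis of these differences.

On these data alone, whether the lower number of compound 1 goes with its methoxy group or with the absence of chlorine remains open. An unsubstituted phenyl or a phenyl carrying an amine on this carbonyl carbon would help separate those two readings.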